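The compounds below may be only part of what the source reports. "The series", "measured", "known", "first", "only" and "open" are said of these compounds alone.

Notes on the shared core of compound 1 `C#CCCCOc1ccc2cc(C(=O)OC)c(=O)oc2c1`. In an assay on cells for inhibition of Amine oxidase [flavin-containing] B (Homo sapiens), read by Amplex Red, with stated times of 30 min and 45 min (a higher number here means a weaker inhibitor, a lower number a stronger inhibitor), compound 1 gives 82.4 nM. Compound 2 `C#CCCCOc1ccc2cc(C(=O)O)c(=O)oc2c1` is reported in this assay only as a limit, > 10000 nM. Compound 3 `C#CCCCOc1ccc2cc(C(=O)Nc3ccc(F)cc3)c(=O)oc2c1` likewise sits in this assay at a limit, > 10000 nM. Compound 2 therefore stands at the limit of > 10000 nM in this assay, at which 2 of the 3 values shown sit, with no number of its own. Next comes compound 4 `C#CCCCOc1ccc2cc(NC(C)=O)c(=O)oc2c1`, which carries acetamido in place of carboxy on an aromatic carbon. Among the measured compounds shown here, the steps that bear on it are an at least 120-fold higher number from compound 1 to compound 2 (2.08 log units; beyond the scatter) and an at least 120-fold higher number from compound 1 to compound 3 (2.08 log units; beyond the scatter), while a step that the two limits leave unreadable from compound 2 to compound 3. The expected outcome in this assay is an at least 3.3-fold lower number from compound 2 to compound 4 (0.52 log units; beyond the scatter), if readable at all. Compound 4 is estimated at 3000 nM, within a range from 400 nM to 20000 nM.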

Compound 4, half-maximal inhibitory concentration: 43.6 nM
For compound 4 the middle estimate is 69-fold (1.84 log units) above the measured one, and the stated range ends above it.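

In this assay, a carbonyl-bearing group on this aromatic carbon can be other than an ester and still keep a low number, as acetamido and methoxycarbonyl cannot be told apart: a 1.9-fold lower number from compound 1 to compound 4 (0.28 log units; within the scatter). Acetamido in place of carboxy gives a large change, with an at least 220-fold lower number from compound 2 to compound 4 (2.36 log units; beyond the scatter). Compound 2 supplies only a limit to that step, not a number: the limit of > 10000 nM in this assay, at which 2 of the 4 values shown sit.

Open, from the compounds shown here alone, is whether a free amine on this aromatic carbon, or a longer acyl chain in place of the acetyl part of acetamido, keeps a number of this size.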